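A Formylthiophene Swap on a Shared Core

The source may hold more compounds than are shown below. What is called first, only, known or untested is meant among the compounds shown, and "the series" means these compounds.

Measured in a functional assay on MV4-11 cells (Homo sapiens) for inhibition, read by resazurin assay, with a stated time of 72 h; on this read-out higher numbers stand for weaker inhibition of growth and lower numbers for stronger inhibition of growth:
compound 1 `O=C1NCCC12CCN(c1c(Cl)cncc1-c1ccoc1)CC2`: 750 nM
compound 2 `Cc1ccsc1-c1cncc(Cl)c1N1CCC2(CCNC2=O)CC1`: 910 nM
compound 3 `O=C1NCCC12CCN(c1c(Cl)cncc1-c1ccc(Cl)s1)CC2`: 560 nM

These three compounds share one core and differ only in the ring group on one aromatic carbon. Compound 3, at 560 nM, stands level with the other two, since neither of its steps leaves the usual scatter of repeated measurements.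

The next compound, compound 4 `O=Cc1sccc1-c1cncc(Cl)c1N1CCC2(CCNC2=O)CC1`, carries 2-formylthiophen-3-yl in place of 5-chlorothiophen-2-yl on an aromatic carbon.

Going by the values given here, three measured steps bear on this change, as each swaps one ring group for another at the same carbon. They are a 1.3-fold lower number from compound 1 to compound 3 (0.13 log units; within the scatter), a 1.6-fold lower number from compound 2 to compound 3 (0.21 log units; within the scatter) and a 1.2-fold higher number from compound 1 to compound 2 (0.08 log units; within the scatter). None of them goes beyond the scatter, so no step beyond the scatter is expected in this assay. Among the compounds with values here, still, no measured compound carries a formyl group, and that gap in the data calls for a wide range. The expected step is a 1.4-fold higher number from compound 3 to compound 4 (0.15 log units; within the scatter). For compound 4 the estimate is 800 nM, with an expected range of 300 nM to 2200 nM.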

Compound 4, concentration for 50% growth inhibition: 28700 nM
Estimate against measurement, compound 4: 36-fold (1.55 log units) below; measured number outside the range, above it.
By their numbers in this assay, from the lowest: compounds 3, 1 and 2 (each within the scatter of the next); then compound 4.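

In this assay, furan-3-yl, 3-methylthiophen-2-yl and 5-chlorothiophen-2-yl on this aromatic carbon gave numbers within the scatter of one another, which made the position look indifferent to the choice of ring group. 2-Formylthiophen-3-yl ends that picture, with a 51-fold higher number from compound 3 to compound 4 (1.71 log units; beyond the scatter), a 32-fold higher number from compound 2 to compound 4 (1.50 log units; beyond the scatter) and a 38-fold higher number from compound 1 to compound 4 (1.58 log units; beyond the scatter), so this carbon, ortho to a large group, does not accept every five-membered aromatic ring alike. Among these four compounds, only compound 4 carries a formyl group, with its double bond outside the aromatic ring, but no data here explain why its number rises so far.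

Compared with the ring groups in compounds 1, 2 and 3, the group in compound 4 differs in more than the added formyl, so these compounds cannot separate the effect of the formyl group from that of the rest of the ring group. Going by these compounds, it remains open whether a plain thiophen-3-yl, or a hydroxymethyl or carboxylic acid in place of the formyl group, would bring the number back towards those of the three earlier compounds.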